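Restoring a ring substituent on compound 3

The source may hold more compounds than are shown below. What is called first, only, known or untested is meant among the compounds shown, and "the series" means these compounds.

In an ADME assay on microsomes from liver (Rattus norvegicus) for metabolic stability, with a stated time of 60 min, tested at 1 uM (on this read-out lower numbers stand for a less stable compound and higher numbers for a more stable compound), compound 3 (`COc1cnc2c(-c3ccnc(OC)c3)cnn2c1`) gives 10%. That lies within the scatter of compound 1 (`COc1cc(-c2cnn3cc(OC)c(C(C)C)nc23)ccn1`) at 14%, whereas compound 2 (`COc1cc(-c2cnn3cc(OC)c(C4CCOC4)nc23)ccn1`) gives 34%. Compound 4 (`COc1cc(-c2cnn3cc(OC)c([C@H]4COC(C)(C)C4)nc23)ccn1`) differs from compound 3 by a group of 7 heavy atoms (6 carbon, 1 oxygen; one five-membered non-aromatic ring with 1 hetero atom) in place of a hydrogen atom, on an aromatic carbon. For the measured compounds named here, two measured steps bear on this change. The nearer precedent is the oxolan-3-yl group, a number 24 percentage points lower from compound 2 to compound 3 (beyond the scatter). The isopropyl group shows only a number 4 percentage points lower from compound 1 to compound 3 (within the scatter). Going by the values given here, the entering group is not identical to oxolan-3-yl, and no measured compound isolates that difference, so the range stays wide. A modest rise in this assay is expected, of the size of a number 22 percentage points higher from compound 3 to compound 4 (beyond the scatter). For compound 4 the estimate is 32%, with an expected range of 14% to 55%.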

Compound 4, percent of the compound remaining: 30%
Compound 4: middle estimate off by 2 percentage points, on the high side; the range from low to high includes it.
By their numbers in this assay, from the lowest: compounds 3 and 1 (each within the scatter of the next); then compounds 4 and 2 (each within the scatter of the next).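

A second five-membered ring with one hetero atom on this aromatic carbon also lifts the read-out in this assay, with a number 20 percentage points higher from compound 3 to compound 4 (beyond the scatter) and, against isopropyl, a number 16 percentage points higher from compound 1 to compound 4 (beyond the scatter). Going from oxolan-3-yl to the larger ring group opens no real gap, with a number 4 percentage points lower from compound 2 to compound 4 (within the scatter), so the two ring groups stand level here. Nothing measured accounts for these steps. Still open, going by these compounds, is whether an amine or an open-chain ether on this carbon would match the ring groups. Also open, on these data alone, is whether the opposite stereoisomer of compound 4 would read the same.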